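A few compounds are considered here, and "the series" means these few. Any claim that something is new, unique, unknown or untested is made for them only; others in the source may bear on it.

Measured in an ADME assay on Caco-2 cells (Homo sapiens) for permeability, read by LC-MS, in the apical to basolateral direction, with a stated time of 60 min, at pH 6.5; a higher number here means that the compound crosses the layer faster, a lower number that the compound crosses the layer more slowly:

- compound 1 `CC1(C[C@@H](O)C(=O)N2N=CC[C@H]2C(=O)NCc2cc(Cl)ccc2-n2cnnn2)CC1`: 9.5 10^-6 cm/s
- compound 2 `CC(C)(C)[C@@H](O)C(=O)N1C[C@H]2C[C@H]2[C@H]1C(=O)NCc1cc(Cl)ccc1-n1cnnn1`: 3.8 10^-6 cm/s

Of these two numbers, compound 1 holds the higher one, and its gap to compound 2 lies beyond the usual scatter. The two compounds differ in more than one place, so that gap cannot be tied to any single group.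

The next compound to be tested is compound 3 `O=C(NCc1cc(Cl)ccc1-n1cnnn1)[C@@H]1CC=NN1C(=O)[C@H](O)C1CCCCC1`. It keeps the rest of compound 1 but carries cyclohexyl in place of (1-methylcyclopropyl)methyl on a saturated chain carbon bound to a carbonyl carbon and an oxygen on a saturated carbon. Among the compounds with values here, no pair of measured compounds shows a change in this one place, so the data offer no direct guide to this swap. The two groups are close in size and neither adds a hydrogen-bond donor or acceptor, so no step beyond the scatter is expected in this assay, with a slight drop at most. The expected result is a 1.2-fold lower number from compound 1 to compound 3 (0.07 log units; within the scatter). For compound 3 the estimated value is 8 10^-6 cm/s, with an expected range from 3.5 10^-6 cm/s to 17 10^-6 cm/s.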

Compound 3, apparent permeability: 19 10^-6 cm/s
Beside the measured number, compound 3's estimate is 2.4-fold (0.38 log units) below it, outside the stated range (above it).
By their numbers in this assay, from the lowest: compound 2; then compounds 1 and 3 (each within the scatter of the next).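

Putting cyclohexyl in place of (1-methylcyclopropyl)methyl, on a saturated chain carbon bound to a carbonyl carbon and an oxygen on a saturated carbon, gives in this assay a 2.0-fold higher number from compound 1 to compound 3 (0.30 log units; within the scatter). Within the data shown here, this is the first comparison in which only this one place differs, and because the step stays within the usual scatter, the two groups cannot be told apart in this measurement, even though one carries a three-membered ring and the other a six-membered ring, both of carbon only. Neither group has a hydrogen-bond donor, a hydrogen-bond acceptor or a net charge, and no measurement is available that would explain the size of this step.

Both groups are made only of carbon, so the compounds shown leave open what an amine or a carboxylic acid at this place would do in this assay. They also leave open whether cyclohexyl would give a similar step on the core of compound 2, which differs from compound 1 in more than one place.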